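Compound 3 to compound 4: nitrophenyl in place of fluorophenyl

The source may report more compounds than this note shows. Statements on the series, on what has been measured and on what is new or still open speak of the compounds shown alone.

compound 1 `CCOC(=O)c1c(C)nc(-c2cccc(C#N)c2)n1OCCC(=O)O` — > 30000 nM
compound 2 `CCOC(=O)c1c(C)nc(-c2cccc(C#N)c2)n1OCc1ccncc1` — 6200 nM
compound 3 `CCOC(=O)c1c(C)nc(-c2cccc(C#N)c2)n1OCc1cccc(F)c1` — 22400 nM

Of the compounds shown here, three on one shared core have been tested in a functional assay on a cell-free system (plasma, Oryctolagus cuniculus) for inhibition, with stated times of 5 min, 1 min and 6 min; a higher number here means a weaker inhibitor, a lower number a stronger inhibitor. For compound 1 the result is only a limit of the assay, > 30000 nM. Compound 2 gives 6200 nM, and compound 3 gives 22400 nM. Of the two numbers shown, compound 3 stands highest, that is, as the weaker of the two inhibitors; its nearest neighbour is compound 2, and the step between them is a 3.6-fold higher number from compound 2 to compound 3 (0.56 log units; beyond the scatter). Against the limit of compound 1, the step of an at least 4.8-fold lower number from compound 1 to compound 2 (0.68 log units; beyond the scatter), whereas the step of an at least 1.3-fold lower number from compound 1 to compound 3 (0.12 log units; that floor lies within the scatter).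

Compound 4 `CCOC(=O)c1c(C)nc(-c2cccc(C#N)c2)n1OCc1ccc([N+](=O)[O-])cc1` differs from compound 3 in one place: 4-nitrophenyl in place of 3-fluorophenyl on a saturated chain carbon bound to an oxygen on an aromatic ring. Going by the values given here, the only measured step that bears on an exchange of one aromatic ring for another at this position is the one from compound 2 to compound 3, and it was modest. A ring carrying two hydrogen-bond acceptors now enters where a ring with none leaves, so a modest drop in the number, toward compound 2, is expected rather than a step beyond the scatter in the other direction. Compound 4 is therefore estimated at 11000 nM, with a range from 4000 nM to 30000 nM. That estimate amounts to an expected step of a 2.0-fold lower number from compound 3 to compound 4 (0.31 log units; beyond the scatter).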

Compound 4, half-maximal inhibitory concentration: 8750 nM
Compound 4: middle estimate off by 1.3-fold (0.10 log units), on the high side; measured number inside the range.
By their numbers in this assay, from the lowest: compounds 2 and 4 (each within the scatter of the next); then compound 3. At a limit, above all of these: compound 1.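

In this assay, 4-nitrophenyl in place of 3-fluorophenyl on the saturated chain carbon gives a 2.6-fold lower number from compound 3 to compound 4 (0.41 log units; beyond the scatter), which shows that the number at this position also moves when one ring of carbon only replaces another. Until now, the only measured exchange of one aromatic ring for another had set pyridin-4-yl against 3-fluorophenyl, leaving open whether a ring of carbon only could match pyridin-4-yl, but the new comparison, a 1.4-fold higher number from compound 2 to compound 4 (0.15 log units; within the scatter), shows that among these compounds a nitrogen in the ring is not required for a number at that level. The remaining step, an at least 3.4-fold lower number from compound 1 to compound 4 (0.53 log units; beyond the scatter), is only a floor and not a measured distance, as it rests on a limit: the limit of > 30000 nM in this assay, at which 1 of the 4 values shown sits.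

The compounds shown do not separate the nitro group from its place on the ring, as 3-fluorophenyl and 4-nitrophenyl differ in both. They also leave open how this assay would read an amine or a methoxy group on the benzyl ring, or a longer chain carrying that ring.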